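This account rests on a few compounds, and the source may have more. Where it says the series, first, only, none or still open, it means among the compounds named here.

Measured compounds, with maximal plasma concentration in an ADME assay on the whole organism (Macaca fascicularis) for pharmacokinetics, at a dose of 1 mg/kg by the oral route; on this read-out lower numbers stand for lower exposure and higher numbers for higher exposure at the dose given:
compound 1 `Cc1sc(N(CC2CC2)[C@H](C)c2ccc(-c3cc(Cl)ccc3-c3nc(=O)o[nH]3)cc2)nc1C(=O)NS(C)(=O)=O` gives 367 nM
compound 2 `Cc1ccc(-c2nc(=O)s[nH]2)c(-c2ccc([C@@H](C)N(CC3CC3)c3nc(C(=O)NS(=O)(=O)C4CC4)c(C4CC4)s3)cc2)c1` gives 6590 nM

Of the two numbers, compound 2 shows the higher one, and the gap to compound 1 lies beyond the usual scatter of this assay . No step between measured compounds that differ in a single place is available, so the two values are taken only as they stand, without a cause being read into them.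

Compound 3 `CONC(=O)c1ccc(C)cc1-c1ccc([C@@H](C)N(CC2CC2)c2nc(C(=O)NS(=O)(=O)C3CC3)c(C3CC3)s2)cc1` remains to be measured. It differs from compound 2 in one place: a group of 5 heavy atoms (2 carbon, 1 nitrogen, 2 oxygen; no ring) in place of a group of 6 heavy atoms (2 carbon, 2 nitrogen, 1 oxygen, 1 sulfur; one five-membered aromatic ring with 3 hetero atoms), on an aromatic carbon. The rest of compound 2 is kept unchanged.

With no measured step of this kind in the series, the size and direction of the effect on exposure are open. For compound 3 the expected outcome is a step of a 2.2-fold lower number from compound 2 to compound 3 (0.34 log units; beyond the scatter), a moderate fall that need not clear the scatter. The estimate for compound 3 in this assay is 3000 nM, with a range from 800 nM to 12000 nM.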

Compound 3, maximal plasma concentration: 5720 nM
For compound 3 the middle estimate is 1.9-fold (0.28 log units) below the measured one; low and high end bracket the measured number.
By their numbers in this assay, from the lowest: compound 1; then compounds 3 and 2 (each within the scatter of the next).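

Position ortho to a large group and para to a methyl group, on the six-membered aromatic ring of carbon only: in this assay, exchanging the five-membered aromatic ring with 3 hetero atoms for methoxycarbamoyl gives a 1.2-fold lower number from compound 2 to compound 3 (0.06 log units; within the scatter). Among the compounds shown here, this is the first single-place step, and it shows that, on this core, the read-out does not depend on that ring being present: the open-chain methoxycarbamoyl, with no ring, gives a value within the scatter of the ring-bearing compound 2, and compound 3 stands at 5720 nM. No measurement in hand bears on why the two groups read alike, so the step stands as an observation only.

One step at one position says nothing about how far this tolerance extends, and a carboxylic acid, a nitrile or a longer alkoxycarbamoyl chain at the same place could read quite differently in this assay. Also open, from the compounds shown here alone, is whether methoxycarbamoyl would behave the same way on the core of compound 1, which differs from compound 3 in more than one place and so gives no direct comparison.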